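Furan-2-yl in Place of Phenyl at the Carbonyl

The source may hold more compounds than are shown below. What is called first, only, known or untested is meant among the compounds shown, and "the series" means these compounds.

Compound 1 `CC(=O)c1ccc2c(c1)C(n1ccccc1=O)=CC(C)(C)O2` gives 7.37 in a functional assay (aorta) with Rattus norvegicus as the target; on this read-out lower numbers stand for lower potency and higher numbers for higher potency (the scale is a negative logarithm). Compound 2 `CC1(C)C=C(n2ccccc2=O)c2cc(C(=O)c3ccccc3)ccc2O1` gives 6.61, and compound 3 `COc1ccc(C(=O)c2ccc3c(c2)C(n2ccccc2=O)=CC(C)(C)O3)cc1` gives 6.15. Compound 2 thus stands second highest of the three numbers, with the drop a number 0.76 log units lower from compound 1 to compound 2 (beyond the scatter) above it and the drop a number 0.46 log units lower from compound 2 to compound 3 (beyond the scatter) below it; the larger drop a number 1.22 log units lower from compound 1 to compound 3 (beyond the scatter) spans both. Compound 4 `CC1(C)C=C(n2ccccc2=O)c2cc(C(=O)c3ccco3)ccc2O1` differs from compound 2 by furan-2-yl in place of phenyl on a carbonyl carbon. Every measured step also altered the group on the carbonyl carbon, and each lowered potency, but none shows how a five-membered aromatic ring with one hetero atom compares with phenyl there. A step close to zero is expected, a number 0.09 log units higher from compound 2 to compound 4 (within the scatter). Compound 4 is therefore estimated at 6.7, within 6.1 to 7.3.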

Compound 4, logarithm of the reciprocal of the active concentration, log(1/C): 6.49
Beside the measured number, compound 4's estimate is 0.21 log units above it; the measured number falls inside the stated range.
By their numbers in this assay, from the lowest: compound 3; then compounds 4 and 2 (each within the scatter of the next); then compound 1.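

In this assay the step is a number 0.12 log units lower from compound 2 to compound 4 (within the scatter) and so puts furan-2-yl and phenyl on a par on this carbonyl carbon, even though furan-2-yl brings a ring oxygen and a hydrogen-bond acceptor. The same change reads a number 0.34 log units higher from compound 3 to compound 4 (beyond the scatter) and a number 0.88 log units lower from compound 1 to compound 4 (beyond the scatter) so that methyl keeps the highest number, with all three aromatic rings beyond the scatter from it. No measurement here offers an explanation for these steps. Still open, on these data alone, is how thiophen-2-yl or pyridin-3-yl would compare with furan-2-yl, and whether ethyl or a longer chain would match methyl.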